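The compounds below may be only part of what the source reports. "The series", "measured", "known", "first", "only" and "open" are said of these compounds alone.

Measured compounds:
- compound 1, `O=C(N/N=C/c1cccc([N+](=O)[O-])c1)Nc1ccc(Oc2ccnc3[nH]ccc23)c(F)c1`: 5140 nM
- compound 2, `COc1ccc(/C=N/NC(=O)Nc2ccc(Oc3ccnc4[nH]ccc34)c(F)c2)c(OC)c1OC`: 8970 nM

Both were tested in a functional assay on PC-3 cells (Homo sapiens) for antiproliferative activity, read by MTT assay, with a stated time of 72 h; a lower number here means a stronger inhibitor, a higher number a weaker inhibitor. In this assay compound 1 gives 5140 nM and compound 2 gives 8970 nM; these two numbers sit within the usual scatter of each other, so neither compound can be set above the other, and compound 1 simply stands alongside compound 2 among the two values known.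

Compound 3, `CN(C)CCn1cccc1/C=N/NC(=O)Nc1ccc(Oc2ccnc3[nH]ccc23)c(F)c1`, has not yet been measured in this assay. It differs from compound 1 in one place: 1-(2-(dimethylamino)ethyl)-1H-pyrrol-2-yl in place of 3-nitrophenyl on a carbon with a double bond to nitrogen. The shared core of compound 1 is kept, and only the group on the carbon with a double bond to nitrogen is exchanged.

For the measured compounds named here, no step between two measured compounds is available to show what such an exchange does here, and the two measured values differ only within the scatter. On that basis no step beyond the scatter is expected in this assay in either direction. Compound 3 is therefore expected to give about 6500 nM in this assay, within a range from 2000 nM to 20000 nM, and the expected step of a 1.3-fold higher number from compound 1 to compound 3 (0.10 log units; within the scatter) is estimated to lie within the scatter.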

Compound 3, half-maximal inhibitory concentration: 1600 nM
Beside the measured number, compound 3's estimate is 4.1-fold (0.61 log units) above it, outside the stated range (below it).
By their numbers in this assay, from the lowest: compound 3; then compounds 1 and 2 (each within the scatter of the next).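

In this assay, putting 1-(2-(dimethylamino)ethyl)-1H-pyrrol-2-yl in place of 3-nitrophenyl gives a 3.2-fold lower number from compound 1 to compound 3 (0.51 log units; beyond the scatter), the first change shown here that lies beyond the usual scatter. This shows that the group on a carbon with a double bond to nitrogen can shift antiproliferative activity, if modestly, while the shared core stays the same. It also shows that a six-membered aromatic ring of carbon only is not needed at this place, as a five-membered aromatic ring with 1 hetero atom, carrying its chain, gives the stronger inhibitor of this pair, but no measurement at hand says why the number falls.

The exchange replaces the ring and adds the chain in a single step, so the compounds shown do not tell whether the lower number goes with the five-membered ring, with the 2-(dimethylamino)ethyl chain, or only with the two together. A plain 1-methyl-1H-pyrrol-2-yl group would test the ring without the amine, while a morpholine in place of the dimethylamino group, or a longer chain, would test how much the amine and the length of its chain matter.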